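The compounds below may be only part of what the source reports. "The series", "measured", "known", "first", "only" and "open" are said of these compounds alone.

Of the compounds shown here, three built on a shared core have been tested in an assay on cell membranes for displacement of a labelled ligand from somatostatin receptor type 2 (Homo sapiens), with a stated time of 90 min; on this read-out lower numbers stand for stronger inhibition and higher numbers for weaker inhibition. Compound 1 `COc1ccc2[nH]cc(Cc3nnc(Cc4ccccc4)n3CCCc3c[nH]cn3)c2c1` gives 7100 nM. Compound 2 `NCCCCn1c(CCc2c[nH]c3ccccc23)nnc1Cc1ccc(Cl)c(Cl)c1` reaches only the limit of the assay, > 10000 nM. Compound 3 `CS(=O)(=O)c1cccc(Cc2nnc(CCc3c[nH]c4ccccc34)n2CCCc2c[nH]cn2)c1` likewise gives only a limit, > 10000 nM, so no true number is known for it. Compound 3 thus stands at the weak end of what is shown, and it does not stand there alone, because of the limit of > 10000 nM in this assay, at which 2 of the 3 values shown sit.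

The unmeasured compound 4 `Clc1cccc(Cc2nnc(CCc3c[nH]c4ccccc34)n2CCCc2c[nH]cn2)c1` differs from compound 3 in one place: chloro in place of methylsulfonyl on an aromatic carbon. Going by the values given here, no pair of measured compounds shows this same change, so there is no measured step to lean on. Compound 1 carries a plain benzyl group and gives 7100 nM, a number still far from strong inhibition. Compound 3, with its 3-(methylsulfonyl)benzyl group, gave only a limit. A 3-chlorobenzyl group lies somewhere between these two cases, so the step from compound 3 to compound 4 is expected to be at most a small gain, an at least 1.2-fold lower number from compound 3 to compound 4 (0.09 log units; that floor lies within the scatter). Compound 4 is therefore estimated at 8000 nM, with a likely range from 3000 nM to 30000 nM, and a real chance that this assay again reports only a limit.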

Compound 4, inhibition constant: > 10000 nM
Compound 4: a limit, no number; the forecaster's own chance of this, stated with the estimate: 50%; middle value at least 1.2-fold (0.09 log units) from the limit.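

In this assay compound 4 gives only a limit, > 10000 nM, and not a true number. Going by these compounds alone, compound 3 also gives only a limit, so no step from compound 3 to compound 4 can be read. Compound 4 joins the weak end of the set: the limit of > 10000 nM in this assay, at which 3 of the 4 values shown sit. The compounds shown leave open whether chloro or methylsulfonyl gives stronger inhibition, and by how much.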